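Loss of the 1H-imidazol-2-yl group on the ring-amine methyl

The source may report more compounds than this note shows. Statements on the series, on what has been measured and on what is new or still open speak of the compounds shown alone.

Compound 1 `c1coc(CN2CCN(CCCc3c[nH]c4ccc(-n5cnnc5)cc34)CC2)c1`, compound 2 `c1c[nH]c(CN2CCN(CCCc3c[nH]c4ccc(-n5cnnc5)cc34)CC2)n1` and compound 3 `CN(C)C(=O)C(c1ccccc1)N1CCN(CCCc2c[nH]c3ccc(-n4cnnc4)cc23)CC1` share one core and differ only in the group carried on the saturated chain carbon bound to an amine nitrogen in a ring. In an assay on CHO cells for displacement of a labelled ligand from 5-hydroxytryptamine receptor 1D (Homo sapiens) (on this read-out higher numbers stand for weaker inhibition and lower numbers for stronger inhibition), compound 1 gives 0.4 nM, compound 2 gives 1.6 nM and compound 3 gives 1 nM. Compound 2 has the highest number of the three; its gap to compound 3 lies within the scatter, while its gap to compound 1 does not, as a 4.0-fold higher number from compound 1 to compound 2 (0.60 log units; beyond the scatter) shows. Compound 4 `CN1CCN(CCCc2c[nH]c3ccc(-n4cnnc4)cc23)CC1` is not yet measured; it differs from compound 2 by hydrogen in place of 1H-imidazol-2-yl on a saturated chain carbon bound to an amine nitrogen in a ring. Within the data shown here, no measured step removes the whole group at this place; the single step in hand exchanges furan-2-yl for 1H-imidazol-2-yl and is modest. Going by these compounds, all three measured groups give low numbers, so the exact ring matters little, but its complete loss is untested. A weakening beyond the scatter is expected, a 5.0-fold higher number from compound 2 to compound 4 (0.70 log units; beyond the scatter). Compound 4 is therefore estimated at 8 nM, within 1.5 nM to 40 nM.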

Compound 4, half-maximal inhibitory concentration: 33 nM
Compound 4: the middle estimate sits 4.1-fold (0.62 log units) below what was measured, within the range that was stated.
By their numbers in this assay, from the lowest: compound 1; then compounds 3 and 2 (each within the scatter of the next); then compound 4.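

Removing the ring at this place costs far more than exchanging it. In this assay hydrogen in place of 1H-imidazol-2-yl gives a 21-fold higher number from compound 2 to compound 4 (1.31 log units; beyond the scatter) and hydrogen in place of furan-2-yl gives an 83-fold higher number from compound 1 to compound 4 (1.92 log units; beyond the scatter), both large, whereas the exchange of one ring for the other gives only a 4.0-fold higher number from compound 1 to compound 2 (0.60 log units; beyond the scatter). The earlier compounds all carried a group here and could not show how much of the low numbers depends on having one; no measurement at hand gives a reason for the size of this loss.

The compounds shown leave open whether an aromatic ring is needed on the saturated chain carbon bound to an amine nitrogen in a ring. A cyclohexyl ring or a plain ethyl chain at this place would separate the need for a ring from the need for bulk alone.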